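This account rests on a few compounds, and the source may have more. Where it says the series, first, only, none or still open, it means among the compounds named here.

Measured compounds:
compound 1 `CN(C(=O)NC(=O)c1ccccc1F)c1nc(C(F)(F)F)c(C(=O)N/N=C/c2cc(C(F)(F)F)cc(C(F)(F)F)c2)s1` — in a functional assay on A549 cells (Homo sapiens) for inhibition, read by MTT assay, with a stated time of 72 h (a higher number here means a weaker inhibitor, a lower number a stronger inhibitor), compound 1 gives 5.43 ug/mL
compound 2 `CNc1nc(C)c(C(=O)N/N=C/c2cc(C(F)(F)F)cc(C(F)(F)F)c2)s1` — in this assay compound 2 reaches only the limit, > 100 ug/mL
compound 3 `CNc1nc(C(F)(F)F)c(C(=O)N/N=C/c2cccc(C(F)(F)F)c2)s1` — in this assay compound 3 likewise reaches only the limit, > 100 ug/mL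

Compound 3 thus stands at a limit of this assay and not at a number; the same is true of compound 2, as the limit of > 100 ug/mL in this assay, at which 2 of the 3 values shown sit, records. For the measured compounds named here, compound 1 is the only compound of the three with a measured number.

Compound 4 `CNc1nc(C(F)(F)F)c(C(=O)N/N=C/c2cc(C(F)(F)F)cc(C(F)(F)F)c2)s1` is not yet measured. Against compound 3 the change is trifluoromethyl in place of hydrogen on an aromatic carbon — trifluoromethyl in place of hydrogen on an aromatic carbon, placed meta to a trifluoromethyl group on the six-membered aromatic ring of carbon only. Going by the values given here, no measured pair shows the size of this step. Compound 2 carries the same doubly substituted ring and sits at the limit, so a step of compound 3 to compound 4 beyond the scatter is not expected in either direction; the estimated step is a number no higher from compound 3 to compound 4 (the limit leaves the size open). Compound 4 is expected to give about 100 ug/mL, with a range of 40 ug/mL to 300 ug/mL, and most likely only a limit again.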

Compound 4, half-maximal inhibitory concentration: > 100 ug/mL
Compound 4: only a limit was reported; the forecaster's own chance of this, stated with the estimate: 65%; the middle value lies on the limit itself.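

In this assay, trifluoromethyl in place of hydrogen on the aromatic carbon, meta to a trifluoromethyl group, does not lift compound 4 off the limit, and compound 2, compound 3 and compound 4 stop at one place: the limit of > 100 ug/mL in this assay, at which 3 of the 4 values shown sit. The steps among these three cannot be read, so neither the added trifluoromethyl nor trifluoromethyl in place of methyl has a size here. For the compounds shown here, the substituent on the nitrogen gives the one readable step: hydrogen in place of ((2-fluorophenyl)carbonyl)carbamoyl gives an at least 18-fold higher number from compound 1 to compound 4 (1.26 log units; beyond the scatter).

Among the compounds shown, only compound 1 carries this nitrogen substituent, so the effect of the ring substitution in its presence remains open. Also open, going by these compounds, is how much of that substituent the number depends on, for instance whether an acetyl group or a plain carbamoyl on the nitrogen would give a measurable value.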